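This account rests on a few compounds, and the source may have more. Where it says the series, first, only, none or still open, it means among the compounds named here.

The measured compounds:
Compound 1 `Cc1ccc(Nc2nc(C)c(C(=O)/C=C/c3ccc(Cl)cc3)s2)cc1` — in a functional assay on PC-3 cells (Homo sapiens) for cytotoxicity, read by MTT assay (a lower number here means a stronger inhibitor, a higher number a weaker inhibitor), compound 1 gives > 25000 nM, a limit of the assay rather than a number.
Compound 2 `COc1cc(/C=C/C(=O)c2sc(Nc3ccc(C)cc3)nc2C)cc(OC)c1OC` — in this assay compound 2 gives > 25000 nM, again a limit.
Compound 3 `Cc1ccc(Nc2nc(C)c(C(=O)/C=C/c3ccccc3)s2)cc1` — in this assay compound 3 gives > 25000 nM, also a limit.

Compound 1 therefore stands only at a limit in this assay, and the two further values shown are limits too: the limit of > 25000 nM in this assay, at which 3 of the 3 values shown sit. Within the data shown here, the single step between measured compounds, a step that the two limits leave unreadable from compound 1 to compound 3, hydrogen in place of chloro on an aromatic carbon, is left unreadable by the two limits, and it concerns a different part of the shared core than the change now considered.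

Compound 4 `Cc1nc(Nc2ccc(Cl)c(Cl)c2)sc1C(=O)/C=C/c1ccc(Cl)cc1` differs from compound 1 as follows: 3,4-dichlorophenyl in place of 4-methylphenyl on a nitrogen on an aromatic ring. Among the measured compounds shown here, no measured step touches this nitrogen, so nothing among the data bears directly on the change, and the one step that exists is unreadable. The expectation for compound 4 in this assay is therefore 25000 nM, estimated to lie between 8000 nM and 100000 nM. From compound 1 this means an expected step of a number no higher from compound 1 to compound 4 (the limit leaves the size open), with a good chance that compound 4 again returns only a limit.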

Compound 4, half-maximal inhibitory concentration: > 25000 nM
Compound 4: no number, only a limit (the forecaster's own chance of this, stated with the estimate: 65%); the middle value sits exactly at the limit.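

Compound 1 and compound 4 both return only a limit in this assay, so the step between them cannot be read. The compounds shown leave open how strong any of them is and whether any change to the shared core alters it, as all rest at one limit: the limit of > 25000 nM in this assay, at which 4 of the 4 values shown sit.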